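Trimming one methoxy from the ketone-side ring of compound 2

The source may report more compounds than this note shows. Statements on the series, on what has been measured and on what is new or still open speak of the compounds shown alone.

Compound 1, `COc1cc(-c2cc(/C=C/C(=O)c3ccc(N)cc3)[nH]n2)cc(OC)c1OC`: -43%
Compound 2, `COc1ccc(C(=O)/C=C/c2cc(-c3cc(OC)c(OC)c(OC)c3)n[nH]2)cc1OC`: -87%

Of the compounds shown here, two have been measured in a functional assay on A498 cells (Homo sapiens) for cytotoxicity, read by sulforhodamine B assay, with a stated time of 48 h, tested at 10 uM; on this read-out lower numbers stand for a stronger effect and higher numbers for a weaker effect at the one concentration tested. Within the data shown here, compound 2 gives the lowest number of the two, with compound 1 as its only neighbour, and the step of a number 44 percentage points lower from compound 1 to compound 2 (beyond the scatter) is the one measured change, a 3,4-dimethoxyphenyl in place of a 4-aminophenyl on the carbonyl carbon.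

Compound 3, `COc1ccc(C(=O)/C=C/c2cc(-c3cc(OC)c(OC)c(OC)c3)n[nH]2)cc1`, differs from compound 2 by hydrogen in place of methoxy on an aromatic carbon. Among the measured compounds shown here, no measured step removes a single methoxy, so the only guide is the large gain from compound 1 to compound 2, which came with the whole ring swapped. Taking one methoxy away leaves compound 3 with a 4-methoxyphenyl, a ring still closer to that of compound 2 than to the 4-aminophenyl of compound 1. A step of moderate size toward weaker effect in this assay is therefore expected, though it could also stay within the scatter. Compound 3 is estimated at -70%, between -95% and -35%, an expected step of a number 17 percentage points higher from compound 2 to compound 3 (beyond the scatter).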

Compound 3, a percentage reported as activity, at one concentration (the size of the read-out at that concentration, not a potency): -57%
For compound 3 the middle estimate is 13 percentage points below the measured one, and the stated range covers the measured number.
By their numbers in this assay, from the lowest: compound 2; then compound 3; then compound 1.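

In this assay, the loss of one methoxy from the 3,4-dimethoxyphenyl is enough to give a number 30 percentage points higher from compound 2 to compound 3 (beyond the scatter), so this place on the ketone-side ring contributes to the effect on its own and not only as part of a whole-ring swap. The 4-methoxyphenyl of compound 3 also differs from the 4-aminophenyl of compound 1, with methoxy in place of amino giving a number 14 percentage points lower from compound 1 to compound 3 (beyond the scatter), which shows that the group at the other ring position matters as well. The earlier change, a number 44 percentage points lower from compound 1 to compound 2 (beyond the scatter), can therefore be read as two separate changes, each beyond the usual scatter, though nothing available bears on the cause of either one.

The compounds shown leave open whether a hydroxyl or a fluorine in the place of the lost methoxy would keep the effect seen with compound 2, and whether an ethoxy group there would strengthen it further. All three numbers also come from a single concentration, so they tell only of a stronger or weaker effect at that concentration.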